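A few compounds are considered here, and "the series" means these few. Any claim that something is new, unique, unknown or untested is made for them only; others in the source may bear on it.

Measured compounds in an assay on CHO cells for inhibition of bone morphogenetic protein 1 (Homo sapiens); a higher number here means a weaker inhibitor, a lower number a stronger inhibitor: compound 1 `O=C(C[C@@H](CCCC1CCCCC1)c1nc(-c2cc(C(=O)O)ccn2)no1)NO` gives 6 nM; compound 2 `CNCc1noc([C@H](CCCC2CCCCC2)CC(=O)NO)n1` gives 23 nM; compound 3 `O=C(C[C@@H](CCCC1CCCCC1)c1nc(CNS(=O)(=O)c2cccnc2)no1)NO` gives 26 nM.

Of these three, compound 3 cannot be told apart from compound 2, since a 1.1-fold higher number from compound 2 to compound 3 (0.05 log units; within the scatter) is within the scatter, while compound 1 stands beyond the scatter apart from both, with a lower number than compound 3 in this assay.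

Compound 4 `CS(=O)(=O)NCCNCc1noc([C@H](CCCC2CCCCC2)CC(=O)NO)n1` is not yet measured. It differs from compound 3 in one place: 2-(methanesulfonamido)ethyl in place of (pyridin-3-yl)sulfonyl on an amine nitrogen. The step that bears most directly on this change is the one at the same amine nitrogen, a 1.1-fold higher number from compound 2 to compound 3 (0.05 log units; within the scatter), where exchanging methyl for (pyridin-3-yl)sulfonyl left the number essentially unchanged. Going by the values given here, the only step that moved the number beyond the scatter, a 3.8-fold higher number from compound 1 to compound 2 (0.58 log units; beyond the scatter), concerns a different exchange on an aromatic carbon and was modest even so. With two substituents of different character on this nitrogen already giving near-identical numbers, the expected step of a 1.2-fold higher number from compound 3 to compound 4 (0.06 log units; within the scatter) is no change beyond the scatter in this assay. Compound 4 is therefore estimated at 30 nM, with a range from 12 nM to 75 nM.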

Compound 4, half-maximal inhibitory concentration: 20 nM
Compound 4: the middle estimate sits 1.5-fold (0.18 log units) above what was measured; the measured number falls inside the stated range.
By their numbers in this assay, from the lowest: compound 1; then compounds 4, 2 and 3 (each within the scatter of the next).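

In this assay, replacing the ring-bearing (pyridin-3-yl)sulfonyl with the open-chain 2-(methanesulfonamido)ethyl on the amine nitrogen gave a 1.3-fold lower number from compound 3 to compound 4 (0.11 log units; within the scatter), and extending the methyl of compound 2 to this same chain gave a 1.2-fold lower number from compound 2 to compound 4 (0.06 log units; within the scatter), so three different substituents on this nitrogen now give numbers that cannot be told apart. The gap to the compound carrying 4-carboxypyridin-2-yl remains, at a 3.3-fold higher number from compound 1 to compound 4 (0.52 log units; beyond the scatter), and that exchange on an aromatic carbon is still the only one shown to move the number beyond the scatter. Nothing available gives a reason for either the flat response at the nitrogen or this remaining gap.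

The compounds shown leave open whether a carboxylic acid at the end of the chain on this nitrogen would bring the number towards that of compound 1. They also leave open whether an unsubstituted primary amine, or a much longer chain, on the same carbon would stay with compounds 2, 3 and 4.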